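Tetrazolylpropyl in place of the carboxyethylbutyl chain

This account rests on a few compounds, and the source may have more. Where it says the series, first, only, none or still open, it means among the compounds named here.

Compound 1 `c1ccc2nc(COc3ccc(CC4CCCC4Cc4nnn[nH]4)cc3)ccc2c1`: 20 nM
Compound 2 `CC(CCc1nnn[nH]1)Cc1ccc(OCc2ccc3ccccc3n2)cc1`: 27 nM
Compound 3 `CCCC(CCC(=O)O)Cc1cccc(OCc2ccc3ccccc3n2)c1`: 70 nM

Of the compounds shown here, three share the quinolinylmethoxy-bearing core and have been measured in a functional assay (lung) for inhibition, with Cavia porcellus as the target; a lower number here means a stronger inhibitor, a higher number a weaker inhibitor. Compound 1 gives 20 nM and compound 2 gives 27 nM; these two values lie within the scatter of each other. Compound 3, with its acid-terminated chain, gives 70 nM, the highest of the three numbers, and its gaps to compound 2 and to compound 1 both lie beyond the scatter.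

Compound 4 `c1cc(CCCCc2nnn[nH]2)cc(OCc2ccc3ccccc3n2)c1` has not yet been measured in this assay. It differs from compound 3 in one place: 3-(1H-tetrazol-5-yl)propyl in place of 1-(2-carboxyethyl)butyl on a saturated chain carbon bound to an aromatic carbon. For the measured compounds named here, no step between two measured compounds mirrors this change, so the expectation rests on what the three values show. Since compound 1 gives 20 nM and compound 2 gives 27 nM, the expected step is a 2.3-fold lower number from compound 3 to compound 4 (0.37 log units; beyond the scatter). Compound 4 is therefore estimated at 30 nM, within a range from 12 nM to 80 nM.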

Compound 4, half-maximal inhibitory concentration: 105 nM
Compound 4: middle estimate off by 3.5-fold (0.54 log units), on the low side; measured number above the stated range.
By their numbers in this assay, from the lowest: compounds 1 and 2 (each within the scatter of the next); then compounds 3 and 4 (each within the scatter of the next).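

In this assay, the exchange of 1-(2-carboxyethyl)butyl for 3-(1H-tetrazol-5-yl)propyl on a saturated chain carbon bound to an aromatic carbon gives a 1.5-fold higher number from compound 3 to compound 4 (0.18 log units; within the scatter). For the compounds shown here, this is the first comparison here of compounds that differ in one place, and it shows that the two chains cannot be told apart at this position in this assay. Nothing measured here accounts for this result.

The step replaces the whole chain at once, so the contribution of the tetrazole ring cannot be separated from that of the rest of the chain. Still open, on these data alone, is how a primary amide in place of the tetrazole ring, or a longer chain carrying the tetrazole ring, would read at this position.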